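This account rests on a few compounds, and the source may have more. Where it says the series, first, only, none or still open, it means among the compounds named here.

Two compounds of the series have numbers in a functional assay on the whole organism (blood) with Rattus norvegicus as the target, with stated times of 24 h and 1 h, at a dose of 5 mg/kg by the intraperitoneal route; on this read-out higher numbers stand for a stronger effect at the one dose given and lower numbers for a weaker effect. Compound 1 `COc1ccc(NC(=O)NS(=O)(=O)N2CCC(CCNC(=O)c3cc(Cl)ccc3OC)CC2)cc1` gives 27% in this assay. Compound 2 `Cc1cccc(C(=O)NCCC2CCN(S(=O)(=O)NC(=O)NC[C@@H]3C[C@@H]4C=C[C@@H]3C4)CC2)n1` gives 20% in this assay, and its number and that of compound 1 lie within the scatter of each other, so neither is set above the other. Compound 3 `O=C(NC[C@@H]1C[C@@H]2C=C[C@@H]1C2)NS(=O)(=O)N1CCC(CCNC(=O)c2nc3ccccc3s2)CC1` differs from compound 2 in one place: 1,3-benzothiazol-2-yl in place of 6-methylpyridin-2-yl on a carbonyl carbon. Going by the values given here, no measured pair shows this change, so its direction is unknown; the step from compound 2 to compound 3 is expected to stay within the scatter, a number 2 percentage points higher from compound 2 to compound 3 (within the scatter). Compound 3 is accordingly expected to give about 22% in this assay, in the range 8% to 40%.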

Compound 3, a percentage reported as activity, at one dose (the size of the read-out at that dose, not a potency): 24%
Beside the measured number, compound 3's estimate is 2 percentage points below it; the measured number falls inside the stated range.
By their numbers in this assay, from the lowest: compounds 2, 3 and 1 (each within the scatter of the next).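

Going by these compounds alone, on the carbonyl carbon, this is the first step measured at this position: in this assay, 1,3-benzothiazol-2-yl in place of 6-methylpyridin-2-yl gives a number 4 percentage points higher from compound 2 to compound 3 (within the scatter). A larger group with a second aromatic ring is thus accommodated here without a change beyond the scatter, in this single pair. Nothing measured on either group bears on this result.

Still open, as far as these compounds go, is whether a phenyl ring carrying a carboxylic acid or an amine at this place would move the number beyond the scatter. Also open, from the compounds shown here alone, is whether the same exchange reads alike on the core of compound 1.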